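This account rests on a few compounds, and the source may have more. Where it says the series, first, only, none or still open, it means among the compounds named here.

Measured so far:
compound 1, `CCc1ccccc1OS(=O)(=O)c1ccc(N2CCN(C)C2=O)cc1`, gives 4600 nM
compound 2, `COc1ccc(OS(=O)(=O)c2ccc(N3CCN(C)C3=O)cc2)cc1OC`, gives 12000 nM

In a functional assay on HT-29 cells (Homo sapiens) for antiproliferative activity, read by sulforhodamine B assay, with a stated time of 48 h (a higher number here means a weaker inhibitor, a lower number a stronger inhibitor), compound 1 stands at the lowest of these two numbers, and compound 2 sits at a number beyond the usual scatter above it. Compound 3, `CN1CCN(c2ccc(S(=O)(=O)Oc3ccc(Cl)cc3)cc2)C1=O`, is still unmeasured. It differs from compound 1 by 4-chlorophenyl in place of 2-ethylphenyl on an oxygen. Going by the values given here, no measured pair shows this change, so there is no step to lean on. The expected step of a 1.0-fold lower number from compound 1 to compound 3 (0.01 log units; within the scatter) is small, in no clear direction, and likely within the scatter. Compound 3 is therefore estimated at 4500 nM, between 1300 nM and 14000 nM.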

Compound 3, half-maximal inhibitory concentration: 12000 nM
The estimate for compound 3 lay 2.7-fold (0.43 log units) below the measured number; the measured number falls inside the stated range.
By their numbers in this assay, from the lowest: compound 1; then compounds 2 and 3 (each within the scatter of the next).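

In this assay, putting 4-chlorophenyl in place of 2-ethylphenyl, on an oxygen whose other neighbour is the sulfonyl sulfur, gives a 2.6-fold higher number from compound 1 to compound 3 (0.42 log units; beyond the scatter) and shows that the number responds to the group at this place. The change swaps the substituent and its ring position together, so this one step cannot separate the two. Nothing available explains the difference.

Going by these compounds, whether 2-chlorophenyl or 4-ethylphenyl would sit closer to compound 1 or to compound 3 remains open. So does the effect of a longer chain, an amine or a carboxylic acid on this ring.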